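Replacing methoxy with ethynyl on the shared core

The source may hold more compounds than are shown below. What is called first, only, known or untested is meant among the compounds shown, and "the series" means these compounds.

In a physicochemical assay for solubility, read by spectrophotometry, in phosphate buffer, with a stated time of 18 h, at pH 7.4 (on this read-out lower numbers stand for lower solubility and higher numbers for higher solubility), compound 3 (`CCc1ccc(-c2nc3c(c(C)nn3-c3ccccc3)c(-c3ccccc3OC)c2C#N)cc1`) gives 7800 nM, the second highest of three numbers. Compound 1 (`CCc1ccc(-c2nc3c(c(C)nn3-c3ccccc3)c(-c3ccccc3Br)c2C#N)cc1`), carrying bromo, gives 1500 nM, and compound 2 (`CCc1ccc(-c2nc3c(c(C)nn3-c3ccccc3)c(-c3ccccc3C(=O)O)c2C#N)cc1`), carrying carboxy, gives 33000 nM. Compound 4 (`C#Cc1ccccc1-c1c(C#N)c(-c2ccc(CC)cc2)nc2c1c(C)nn2-c1ccccc1`) has ethynyl in place of methoxy on an aromatic carbon. Within the data shown here, two measured steps bear on this change: a 5.2-fold higher number from compound 1 to compound 3 (0.72 log units; beyond the scatter) and a 4.2-fold lower number from compound 2 to compound 3 (0.63 log units; beyond the scatter). Among the measured compounds shown here, both are modest, and no ethynyl compound has yet been measured. Compound 1 at 1500 nM is taken as the nearer guide, so a modest step downward is expected in this assay. The estimated change is a 2.6-fold lower number from compound 3 to compound 4 (0.41 log units; beyond the scatter). Compound 4 is expected at 3000 nM, with an estimated range of 1000 nM to 8000 nM.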

Compound 4, solubility: 46000 nM
Beside the measured number, compound 4's estimate is 15-fold (1.19 log units) below it; the whole stated range lies below it.
By their numbers in this assay, from the lowest: compound 1; then compound 3; then compounds 2 and 4 (each within the scatter of the next).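

At this position, ortho to a large group, this assay shows a 5.9-fold higher number from compound 3 to compound 4 (0.77 log units; beyond the scatter) and a 31-fold higher number from compound 1 to compound 4 (1.49 log units; beyond the scatter) for ethynyl, so a group with 0 hydrogen-bond donors and 0 hydrogen-bond acceptors can stand at the high end of this small set. The step of a 1.4-fold higher number from compound 2 to compound 4 (0.14 log units; within the scatter) leaves ethynyl and carboxy unseparated, so the high end is not held by carboxy alone. No evidence given here accounts for this result. Going by these compounds, whether an amine, or a longer chain ending in a triple bond, would keep ethynyl's number remains open.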